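The source may report more compounds than this note shows. Statements on the series, on what has been measured and on what is new or still open speak of the compounds shown alone.

Compounds measured so far:
compound 1, `COc1ccc(-c2cc(=O)c3c(OC)cc(OC)cc3n2C)cc1` — a functional assay on HepG2 cells (Homo sapiens) for antiproliferative activity, with a stated time of 72 h; a lower number here means that less compound is needed, a higher number that more compound is needed for the effect: "not determined" (no result reported)
compound 2, `COc1ccc(-c2cc(=O)c3c(OC)cc(OC)cc3n2S(=O)(=O)c2cccc([N+](=O)[O-])c2)cc1` — this assay: > 39600 nM
compound 3, `COc1ccc(-c2cc(=O)c3c(OC)cc(OC)cc3n2S(=O)(=O)c2ccc(C#N)cc2)cc1` — this assay: > 17200 nM

Compound 1 carries a methyl on the aromatic nitrogen of the shared core and has no result in this assay; its value is given only as "not determined" (no result reported). Compound 2 reaches only a limit of the assay, > 39600 nM, and not a number. Compound 3 likewise stops at a limit, > 17200 nM. The step between them, a step that the two limits leave unreadable from compound 2 to compound 3, therefore cannot be read, because both ends sit at limits the limit of > 17200 nM in this assay, at which 1 of the 3 values shown sits, and (the limit of > 39600 nM in this assay, at which 1 of the 3 values shown sits).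

The change from compound 1 to the unmeasured compound 4, `COc1ccc(-c2cc(=O)c3c(OC)cc(OC)cc3n2S(=O)(=O)c2ccc(Br)cc2)cc1`, is (4-bromophenyl)sulfonyl in place of methyl on an aromatic nitrogen. Going by the values given here, no measured step bears directly on this change, since compound 1 has no number to start from. What the data do show is that both compounds with an arylsulfonyl group on that nitrogen, compound 2 and compound 3, remain at limits in this assay. Compound 4 carries the same kind of group and is expected to behave in the same way, most likely returning a limit rather than a readable number; its half-maximal effective concentration is estimated at 30000 nM, within the range 8000 nM to 100000 nM.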

Compound 4, half-maximal effective concentration: 16300 nM
Beside the measured number, compound 4's estimate is 1.8-fold (0.26 log units) above it, and the stated range covers the measured number.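

In this assay compound 4 gives 16300 nM, so (4-bromophenyl)sulfonyl on the aromatic nitrogen yields a readable number. The other two arylsulfonyl compounds shown stop at limits. On the sulfonyl sulfur, 4-bromophenyl in place of 3-nitrophenyl gives an at least 2.4-fold lower number from compound 2 to compound 4 (0.38 log units; beyond the scatter), while bromo in place of cyano on an aromatic carbon gives an at least 1.0-fold lower number from compound 3 to compound 4 (0.02 log units; that floor lies within the scatter). Compound 3 stands at a limit and not a number, and its step gives only a floor because of it: the limit of > 17200 nM in this assay, at which 1 of the 4 values shown sits.

Compound 1 has no number in this assay, so the change from methyl to (4-bromophenyl)sulfonyl on the aromatic nitrogen still has no measured size. Also open, going by these compounds, is whether an amine or a carboxylic acid in place of bromo on the phenyl ring would give a number in this assay, and how such a number would stand against that of compound 4.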